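From ethyl to isopropyl at the assay limit

The source may hold more compounds than are shown below. What is called first, only, known or untested is meant among the compounds shown, and "the series" means these compounds.

In a functional assay on Hep 3B2 cells (Homo sapiens) for inhibition, read by sulforhodamine B assay, with a stated time of 72 h (a lower number here means a stronger inhibitor, a higher number a weaker inhibitor), compound 1 (`C[C@H](Nc1ncnc2[nH]cnc12)c1nn(-c2cccnc2)c2cc(F)ccc12`) gives 34500 nM. Compound 2 (`CC[C@H](Nc1ncnc2[nH]cnc12)c1nn(-c2cccnc2)c2cc(F)ccc12`) returns only a limit of the assay, > 40000 nM. Compound 3 (`CC(C)[C@H](Nc1ncnc2[nH]cnc12)c1nn(-c2cccnc2)c2cc(F)ccc12`) differs from it by methyl in place of hydrogen on a saturated chain carbon bound to two saturated chain carbons, a methyl in place of hydrogen on a saturated chain carbon bound to two saturated chain carbons. Within the data shown here, the one measured step bearing on this is an at least 1.1-fold higher number from compound 1 to compound 2 (0.06 log units; that floor lies within the scatter), also a methyl in place of hydrogen, and its size is known only as a floor. No change beyond the scatter is therefore expected, and any drift would be towards a higher number. The expected step is a step that the limit leaves unreadable from compound 2 to compound 3. Compound 3 is estimated at 45000 nM, within an expected range of 25000 nM to 90000 nM.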

Compound 3, half-maximal inhibitory concentration: > 40000 nM
Compound 3 ended at the assay's limit; the forecaster's own chance of this, stated with the estimate: 75%; the middle value is on the limit's open side.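

In this assay, compound 3 gives > 40000 nM, which is a limit of the assay and not a number. Isopropyl in place of methyl shows an at least 1.1-fold higher number from compound 1 to compound 3 (0.06 log units; that floor lies within the scatter), so this larger group adds a second floor, while the step between the two compounds at the limit cannot be read. Among these compounds, with ethyl and isopropyl both at the limit, this position yields only one readable value: the limit of > 40000 nM in this assay, at which 2 of the 3 values shown sit. The compounds shown leave open whether an amine or a carboxylic acid on this chain would give a value inside the assay's range.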